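Growth inhibition notes: fluoro in place of trifluoromethoxy

The source may report more compounds than this note shows. Statements on the series, on what has been measured and on what is new or still open speak of the compounds shown alone.

Series so far, measured in a functional assay on the whole organism for inhibition, with Lemna aequinoctialis as the target, with a stated time of 7 days, tested at 5 ug/mL (on this read-out higher numbers stand for more inhibition of growth at the one concentration tested and lower numbers for less inhibition of growth), at the single concentration:

- compound 1 `O=C1Nc2ccc(F)cc2/C1=N/NC(=S)Nc1cccc(C(F)(F)F)c1` gives 0%
- compound 2 `O=C1Nc2ccc(F)cc2/C1=N/NC(=S)Nc1ccc(OC(F)(F)F)cc1` gives 10%
- compound 3 `O=C1Nc2ccc(F)cc2/C1=N/NC(=S)Nc1ccccc1F` gives 20%

Compound 2 with 10% holds the middle of the three numbers, and its gaps to compound 1 and to compound 3 are both within the usual scatter. All three values sit low on the scale.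

Next in line is compound 4 `O=C1Nc2ccc(F)cc2/C1=N/NC(=S)Nc1ccc(F)cc1`, which has fluoro in place of trifluoromethoxy on an aromatic carbon, para to a large group: fluoro in place of trifluoromethoxy on an aromatic carbon. Within the data shown here, no measured pair differs in one place only, so the data give no direct size for such a change. The nearest guide is compound 3 , which also carries a fluoro on the varied ring and gives 20% in this assay. The expected change is small and upward, an estimated a number 5 percentage points higher from compound 2 to compound 4 (within the scatter), and it stays within the scatter. For compound 4 the expected value is 15%, with an estimated range from 0% to 30%.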

Compound 4, percent growth inhibition at one concentration: 10%
The estimate for compound 4 lay 5 percentage points above the measured number, and the stated range covers the measured number.
By their numbers in this assay, from the lowest: compounds 1, 2, 4 and 3 (each within the scatter of the next, the first and the last beyond it).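

In this assay, among these compounds, the first one-place comparison at this position gives no change at the digits printed from compound 2 to compound 4 (within the scatter), so fluoro in place of trifluoromethoxy on an aromatic carbon, para to a large group, produces no readable difference despite the loss of most of the heavy atoms of that substituent. The second comparison, 4-fluorophenyl in place of 2-fluorophenyl on an amide-type nitrogen, gives a number 10 percentage points lower from compound 3 to compound 4 (within the scatter), so this read-out does not separate these two placings of the fluoro. Nothing available offers an explanation for either result.

As far as these compounds go, it remains open whether an amine, a carboxylic acid or a methoxy group on the same aromatic carbon would move growth inhibition beyond the scatter. The compounds shown also leave open what a hydrogen in place of the fluoro on the shared core would do.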